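Amide aryl swap on the nitrobenzofurazan thioether ester series

The compounds below may be only part of what the source reports. "The series", "measured", "known", "first", "only" and "open" are said of these compounds alone.

Working notes. The series shares the core seen in compound 1 `COc1ccccc1NC(=O)CCC(=O)OCCCCCCSc1ccc([N+](=O)[O-])c2nonc12`; compound 2 `O=C(CCC(=O)OCCCCCCSc1ccc([N+](=O)[O-])c2nonc12)Nc1cccc(Cl)c1` and compound 3 `COc1ccc(NC(=O)CCC(=O)OCCCCCCSc2ccc([N+](=O)[O-])c3nonc23)cc1OC` differ from it only in the aryl group on the amide-type nitrogen. In an ADME assay on L02 cells (Homo sapiens) for cytotoxicity, read by MTT assay, with a stated time of 72 h (a lower number here means a stronger inhibitor, a higher number a weaker inhibitor), compound 1 gives 4490 nM and compound 2 gives 6930 nM. The one step between measured compounds, a 1.5-fold higher number from compound 1 to compound 2 (0.19 log units; within the scatter), leaves the two numbers within the scatter of each other, so compound 2 cannot be separated from compound 1 on the numbers shown.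

The step to compound 3 is 3,4-dimethoxyphenyl in place of 3-chlorophenyl on an amide-type nitrogen. Among the compounds with values here, the only measured step that bears on it is the aryl exchange on the same nitrogen, a 1.5-fold higher number from compound 1 to compound 2 (0.19 log units; within the scatter), which did not move the number beyond the scatter. Within the data shown here, nothing measured so far points to a larger effect of a further aryl exchange at that position, so no step beyond the scatter is expected in this assay.

Compound 3 is therefore expected to give 5500 nM, within a range of 2500 nM to 12000 nM, which corresponds to an expected step of a 1.3-fold lower number from compound 2 to compound 3 (0.10 log units; within the scatter).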

Compound 3, half-maximal inhibitory concentration: 4100 nM
For compound 3 the middle estimate is 1.3-fold (0.13 log units) above the measured one; the measured number falls inside the stated range.
By their numbers in this assay, from the lowest: compounds 3, 1 and 2 (each within the scatter of the next).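

Working notes on the position. In this assay, within the data shown here, neither a 1.7-fold lower number from compound 2 to compound 3 (0.23 log units; within the scatter) nor a 1.1-fold lower number from compound 1 to compound 3 (0.04 log units; within the scatter) leaves the scatter, so a third aryl group on the amide-type nitrogen still yields no step that can be separated from repeat measurement. The change from 3-chlorophenyl, with 7 heavy atoms and 0 hydrogen-bond acceptors, to 3,4-dimethoxyphenyl, with 10 heavy atoms and 2 hydrogen-bond acceptors, is larger in these counts than a simple swap of one aryl group for another, yet it gives no readable difference in this assay, and the three compounds cannot be ranked by their numbers. No supporting data are available that could account for this result.

On these data alone, whether an amine or a carboxylic acid on the aryl group, or a longer chain in place of the one joining the ester to the sulfur, would take the number beyond the scatter remains open. The three compounds differ only on the amide-type nitrogen, so this reading applies to that position alone and says nothing about the rest of the shared core.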